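The compounds below may be only part of what the source reports. "The series", "measured", "known", "first", "only" and "open" are said of these compounds alone.

Measured compounds:
compound 1, `O=c1[nH]ccc2nc(N3CCC(Oc4ccccc4C(F)(F)F)CC3)sc12`, 85 nM
compound 2, `O=c1[nH]cnc2nc(N3CCC(Oc4ccccc4C(F)(F)F)CC3)sc12`, 7 nM

In an assay on microsomes from liver for inhibition of acyl-CoA desaturase 1 (Rattus norvegicus) (a lower number here means a stronger inhibitor, a higher number a weaker inhibitor), compound 2 gives 7 nM, the lowest of the two numbers; compound 1 gives 85 nM, a higher number that lies beyond the scatter. Compound 3, `O=c1[nH]c(CO)nc2nc(N3CCC(Oc4ccccc4C(F)(F)F)CC3)sc12`, differs from compound 2 by hydroxymethyl in place of hydrogen on an aromatic carbon. Within the data shown here, no measured pair shows this change, so its effect is unknown. One expects at most a small step, estimated as a 1.7-fold higher number from compound 2 to compound 3 (0.23 log units; within the scatter), probably toward a higher number, possibly none beyond the scatter. Compound 3 is estimated at 12 nM, with a range from 3 nM to 50 nM.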

Compound 3, half-maximal inhibitory concentration: 2 nM
Compound 3: the middle estimate sits 6.0-fold (0.78 log units) above what was measured; the measured number lies below the stated range.
By their numbers in this assay, from the lowest: compound 3; then compound 2; then compound 1.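

In this assay, hydroxymethyl in place of hydrogen on the aromatic carbon between two ring nitrogen atoms gives a 3.5-fold lower number from compound 2 to compound 3 (0.54 log units; beyond the scatter), a modest step beyond the scatter. This position therefore accepts a substituent without loss and even with a gain, which compound 2, with only hydrogen there, could not show. Nothing available accounts for this gain.

From the compounds shown here alone, it remains open whether the gain depends on the hydroxyl oxygen or on the added carbon, which a simple methyl or a methoxymethyl group could separate. Going by these compounds, how an aminomethyl group, a carboxylic acid or a longer chain would fare at this carbon also remains unknown.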